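A few compounds are considered here, and "the series" means these few. Any claim that something is new, unique, unknown or untested is made for them only; others in the source may bear on it.

Compound 1 `CCCc1nc(-c2ccccc2)c(CNCCCN2CCN(c3cccc(OC)c3)CC2)o1` and compound 2 `CCCc1nc(-c2ccccc2)c(CNCCN2CCN(c3cccc(C(F)(F)F)c3)CC2)o1` share the same core and were both tested in an assay on HEK293 cells for inhibition of Voltage-dependent T-type calcium channel subunit alpha-1G (Homo sapiens), read by fluorescence, tested at 10 uM; a higher number here means more inhibition at the concentration tested (going by the name of the read-out), a lower number less inhibition. Compound 1 gives 36.4%, the lower of the two numbers seen so far. Compound 2 gives 56.3%, a value that lies beyond the usual scatter above compound 1. Compound 2 differs from compound 1 in more than one place, so these two values only show that compound 2 inhibits more at the concentration tested; they do not separate the effect of any single change.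

Compound 3 `CCCc1nc(-c2ccccc2)c(CNCCCN2CCN(c3cccc(F)c3)CC2)o1` has not yet been measured in this assay. It differs from compound 1 in one place only, namely (fluoro in place of methoxy on an aromatic carbon), so that a 3-methoxyphenyl becomes a 3-fluorophenyl. Among the compounds with values here, no measured pair shows this exact change, so the size of the step is unknown; the expectation is a small step, a number 3.6 percentage points higher from compound 1 to compound 3 (within the scatter), which is none beyond the scatter. Compound 3 is therefore estimated to give 40% in this assay, with a range from 20% to 60%.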

Compound 3, a percentage reported as inhibition, at one concentration (the size of the read-out at that concentration, not a potency): 68.9%
Compound 3: the middle estimate sits 28.9 percentage points below what was measured; measured number outside the range, above it.
By their numbers in this assay, from the lowest: compound 1; then compound 2; then compound 3.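

Within the data shown here, this is the first pair that differs in one place only, so the change can be read on its own: in this assay, replacing the 3-methoxyphenyl with a 3-fluorophenyl gives a number 32.5 percentage points higher from compound 1 to compound 3 (beyond the scatter). The substituent on this aromatic carbon therefore matters, since exchanging methoxy for fluoro while the shared core and the chain stay the same is enough to produce a large change in inhibition at the concentration tested. Nothing available explains why the fluoro compound inhibits more than the methoxy compound.

The compounds shown leave open whether this result is specific to fluoro or would also appear with another group on the same aromatic carbon, such as chloro, methyl, nitrile or simply hydrogen. They also leave open whether fluoro would have a similar effect with the different chain of compound 2, which carries a trifluoromethyl group, and how the compounds compare in potency, as each number comes from a single concentration.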